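A few compounds are considered here, and "the series" means these few. Any claim that something is new, unique, unknown or untested is made for them only; others in the source may bear on it.

Measured so far:
- compound 1, `Cc1c(C(=O)N=C(N)N)ccc(Cl)c1S(C)(=O)=O`: 1300 nM
- compound 2, `CCCCCc1cc(C)c(C(=O)N=C(N)N)cc1S(C)(=O)=O`: 27 nM
- compound 3, `Cc1cc(-c2cc(Cl)cc(Cl)c2)c(S(C)(=O)=O)cc1C(=O)N=C(N)N`: 130 nM

All three values come from a functional assay for inhibition of sodium/hydrogen exchanger (Oryctolagus cuniculus); on this read-out higher numbers stand for weaker inhibition and lower numbers for stronger inhibition. Compound 3 holds the second highest of the three numbers: compound 2 sits closest to it with a lower number, and compound 1 lies furthest away with a higher number.

The next compound, compound 4, `Cc1cc(O)c(S(C)(=O)=O)cc1C(=O)N=C(N)N`, differs from compound 3 in one place: hydroxy in place of 3,5-dichlorophenyl on an aromatic carbon. A large two-ring substituent is thus exchanged for a single small group on the shared core.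

Among the compounds with values here, only one measured step touches this position. The step of a 4.8-fold higher number from compound 2 to compound 3 (0.68 log units; beyond the scatter) shows that changing the group at this site moves the read-out in this assay by a modest but real amount. Compound 1, which carries a single chlorine atom rather than a larger carbon chain or ring, gives the highest number of the three, though it also differs from compound 3 elsewhere, so this is only a hint. Taken together, a small group at this site is expected to raise the number further, and compound 4 is expected to show a step of a 4.6-fold higher number from compound 3 to compound 4 (0.66 log units; beyond the scatter) relative to compound 3. The estimated value for compound 4 is 600 nM, expected to fall between 150 nM and 2500 nM.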

Compound 4, half-maximal inhibitory concentration: 220 nM
Beside the measured number, compound 4's estimate is 2.7-fold (0.44 log units) above it; measured number inside the range.
By their numbers in this assay, from the lowest: compound 2; then compounds 3 and 4 (each within the scatter of the next); then compound 1.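

In this assay, replacing 3,5-dichlorophenyl with hydroxy gives a 1.7-fold higher number from compound 3 to compound 4 (0.23 log units; within the scatter) and so does not separate the two groups, even though one brings a six-membered aromatic ring and two chlorine atoms and the other a single oxygen atom. Heavy-atom count therefore does not sort the numbers at this position, and compound 3 and compound 4 go against any trend that ties a larger group to a lower or higher number. Pentyl is what stands apart, since hydroxy in its place gives an 8.1-fold higher number from compound 2 to compound 4 (0.91 log units; beyond the scatter) and this step, unlike the one between compound 3 and compound 4, lies beyond the scatter, yet no measurement at hand explains the difference.

On these data alone, whether the lower number of compound 2 belongs to pentyl alone or to carbon chains more widely remains open, and a propyl or heptyl chain at this site would address that. An amine or a methoxy group here would show whether other small groups also read like hydroxy on the shared core.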